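The source may report more compounds than this note shows. Statements on the series, on what has been measured and on what is new or still open speak of the compounds shown alone.

Measured so far:
Compound 1 `CC(C)(C)N(NC(=O)c1ccccc1)C(=O)c1ccccc1Cl` — in an assay on cells for agonist activity at ecdysone receptor (Bombyx mori), read by a luciferase reporter, with a stated time of 24 h (on this read-out higher numbers stand for an effect only at larger amounts of compound and lower numbers for an effect already at smaller amounts), compound 1 gives 75.9 nM.
Compound 2 `CC(C)(C)N(NC(=O)c1ccccc1)C(=O)c1ccccc1I` — in this assay compound 2 gives 105 nM.

Within the data shown here, compound 1 holds the lower of the two numbers, but its only neighbour lies within the scatter: a 1.4-fold higher number from compound 1 to compound 2 (0.14 log units; within the scatter), a swap of iodo in place of chloro on an aromatic carbon of one benzoyl ring. The two compounds are therefore not told apart, and this single step is all the series offers.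

The next compound, compound 3 `CC(C)(C)N(NC(=O)c1cccc(C#N)c1)C(=O)c1ccccc1Cl`, leaves that halogen ring untouched and instead changes the other benzoyl ring: cyano in place of hydrogen on an aromatic carbon. Among the measured compounds shown here, no measured step concerns this ring, nor a change of this kind; the one step available, a 1.4-fold higher number from compound 1 to compound 2 (0.14 log units; within the scatter), sits on a different ring and involves a different kind of group, so it gives no guide to the effect of the nitrile. In the absence of any bearing comparison, the working expectation is no step beyond the scatter, with the range kept wide to allow for either direction.

For compound 3 the expected step is a 1.1-fold lower number from compound 1 to compound 3 (0.04 log units; within the scatter). Compound 3 is accordingly estimated at 70 nM, within 25 nM to 200 nM.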

Compound 3, half-maximal effective concentration: 955 nM
Compound 3: the middle estimate sits 14-fold (1.13 log units) below what was measured; measured number outside the range, above it.
By their numbers in this assay, from the lowest: compounds 1 and 2 (each within the scatter of the next); then compound 3.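

In this assay, among these compounds, the benzoyl ring without the halogen proves sensitive to substitution: phenyl to 3-cyanophenyl (a 13-fold higher number from compound 1 to compound 3 (1.10 log units; beyond the scatter)) is the first change to move the number beyond the scatter, whereas the swap of iodo for chloro (a 1.4-fold higher number from compound 1 to compound 2 (0.14 log units; within the scatter)) left its pair untold apart. A single cyano group on an aromatic carbon, meta to a large group, is therefore enough to shift the effect to clearly larger amounts of compound, although one group at one place establishes no trend across substituents. No available measurement bears on what lies behind this step.

The compounds shown leave open whether this loss belongs to the nitrile itself or would follow any group at this carbon, a question on which a fluoro, a methyl or a methoxy group at the same place would bear. Also open, on these data alone, is how an amine or a carboxylic acid would behave there, and whether a cyano group elsewhere on this ring would give a step of similar size.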